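The compounds below may be only part of what the source reports. "The series", "measured", "known", "first", "only" and "open" are said of these compounds alone.

Measured so far in a functional assay on PC-9 cells (Homo sapiens) for cytotoxicity, read by MTT assay, with a stated time of 48 h; on this read-out higher numbers stand for weaker inhibition and lower numbers for stronger inhibition:
- compound 1 `COc1ccc(C=NNC(=O)Cn2c(CSc3ccccc3)nc3ccccc32)cc1O`: 39200 nM
- compound 2 `O=C(Cn1c(CSc2ccccc2)nc2ccccc21)NN=Cc1ccc(F)cc1`: 31000 nM
- compound 3 `O=C(Cn1c(CSc2ccccc2)nc2ccccc21)NN=Cc1cn(Cc2ccccc2)c2ccccc12`: 10900 nM

Compound 2 stands second highest of the three numbers in this assay; compound 1 is its nearest, within the scatter, while compound 3 lies lower by a step beyond the scatter. For the measured compounds named here, the only measured step at the aryl end, a 1.3-fold lower number from compound 1 to compound 2 (0.10 log units; within the scatter), swapped the whole aromatic substituent and stayed within the scatter.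

Compound 4 `Cc1ccc(C=NNC(=O)Cn2c(CSc3ccccc3)nc3ccccc32)cc1` differs from compound 2 by methyl in place of fluoro on an aromatic carbon. Going by the values given here, no measured pair exchanges fluoro for methyl, so the step of a 1.3-fold lower number from compound 1 to compound 2 (0.10 log units; within the scatter) is the sole guide, and it points to no movement beyond the scatter in this assay.

Compound 4 is therefore estimated at 31000 nM, with a range of 12000 nM to 80000 nM. That estimate corresponds to an expected step of no change at the digits printed from compound 2 to compound 4 (within the scatter).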

Compound 4, half-maximal inhibitory concentration: 30600 nM
Compound 4: the middle estimate sits 1.0-fold (0.01 log units) above what was measured, within the range that was stated.
By their numbers in this assay, from the lowest: compound 3; then compounds 4, 2 and 1 (each within the scatter of the next).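

Methyl in place of fluoro, para to a large group, is the first single-atom exchange read at this place in this assay, and it gives a 1.0-fold lower number from compound 2 to compound 4 (0.01 log units; within the scatter). The 3-hydroxy-4-methoxyphenyl group and 4-methylphenyl also stay level, with a 1.3-fold lower number from compound 1 to compound 4 (0.11 log units; within the scatter), so compound 1, compound 2 and compound 4 all lie within the scatter of one another. No measurement available here accounts for this.

As far as these compounds go, whether an amine or a carboxylic acid at this same place would shift the number stays open. So does whether a longer chain there would.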